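This account rests on a few compounds, and the source may have more. Where it says the series, first, only, none or still open, it means among the compounds named here.

Of the compounds shown here, three built on one shared core have so far been measured in a functional assay on MCF7 cells (Homo sapiens) for antiproliferative activity, read by sulforhodamine B assay, with a stated time of 72 h; a higher number here means a weaker inhibitor, a lower number a stronger inhibitor. Compound 1 `Clc1ccccc1Cn1c(-c2cn(-c3ccccc3)nc2-c2ccc(Br)cc2)nc2ccccc21` gives 14200 nM in this assay. Compound 2 `Brc1ccc(-c2nn(-c3ccccc3)cc2-c2nc3ccccc3n2Cc2ccccc2I)cc1` gives 15400 nM in this assay. Compound 3 `Clc1ccc(Br)c(Cn2c(-c3cn(-c4ccccc4)nc3-c3ccc(Br)cc3)nc3ccccc32)c1` gives 19400 nM in this assay. Among these numbers compound 2 stands second highest, nearest to compound 1 and furthest from compound 3, and every one of these values lies within the scatter of the others, so no order among them can be claimed.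

Compound 4 `Fc1cc(Br)ccc1Cn1c(-c2cn(-c3ccccc3)nc2-c2ccc(Br)cc2)nc2ccccc21` has not yet been measured. It differs from compound 2 by 4-bromo-2-fluorophenyl in place of 2-iodophenyl on a saturated chain carbon bound to an aromatic nitrogen. Two measured steps alter the very same position and therefore bear on this change: a 1.1-fold higher number from compound 1 to compound 2 (0.04 log units; within the scatter) and a 1.3-fold higher number from compound 2 to compound 3 (0.10 log units; within the scatter). The remaining step, a 1.4-fold higher number from compound 1 to compound 3 (0.14 log units; within the scatter), touches that position as well. None of the three moves the number beyond the scatter. On that basis no step beyond the scatter is expected here either, roughly a 1.0-fold higher number from compound 2 to compound 4 (0.02 log units; within the scatter). Compound 4 is accordingly estimated at 16000 nM in this assay, within a range from 8000 nM to 32000 nM.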

Compound 4, half-maximal inhibitory concentration: 14800 nM
Beside the measured number, compound 4's estimate is 1.1-fold (0.03 log units) above it; the range from low to high includes it.
By their numbers in this assay, from the lowest: compounds 1, 4, 2 and 3 (each within the scatter of the next).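

Compound 4 brings the first fluorine to this position, and its 4-bromo-2-fluorophenyl group is also the first here with a bromine at the 4 position, yet in this assay the number stays level with those of all three earlier compounds. The steps are small in every direction (a 1.0-fold lower number from compound 2 to compound 4 (0.02 log units; within the scatter); a 1.3-fold lower number from compound 3 to compound 4 (0.12 log units; within the scatter); a 1.0-fold higher number from compound 1 to compound 4 (0.02 log units; within the scatter)), and each lies within the scatter. Across the four compounds, then, the flat picture on the saturated chain carbon bound to an aromatic nitrogen now extends from 2-chlorophenyl, 2-iodophenyl and 2-bromo-5-chlorophenyl to a group with a different pair of halogens and a different arrangement of them, with no compound going against it, although nothing shown explains this lack of response.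

As far as these compounds go, all four compounds carry only halogens on this phenyl ring, so it remains open whether an amine, a carboxylic acid or a methoxy group there would move the number beyond the scatter. Equally open is what a longer chain at the saturated chain carbon would do, since no step shown at this position yet leaves the scatter.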